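The source may report more compounds than this note shows. Statements on the series, on what has been measured and on what is new or still open speak of the compounds shown alone.

The measured compounds:

Compound 1, `CC(C)(C)/N=c1\c(O)c(O)\c1=N/Cc1ccc(Cl)cc1Cl`; in a functional assay for inhibition, with Rattus norvegicus as the target (on this read-out lower numbers stand for stronger inhibition and higher numbers for weaker inhibition), compound 1 gives 1300 nM.
Compound 2, `CC(C)(C)/N=c1\c(O)c(O)\c1=N/Cc1ccc(Cl)cc1`; in this assay compound 2 gives 1700 nM.
Compound 3, `CCC(C)(C)/N=c1\c(O)c(O)\c1=N/Cc1ccc(F)cc1`; in this assay compound 3 gives 360 nM.

Compounds 1 and 2 share a core and differ in one place: chloro in place of hydrogen on an aromatic carbon. That change made a 1.3-fold lower number from compound 2 to compound 1 (0.12 log units; within the scatter), so the two values cannot be told apart by this read-out. Compound 3 has a different core; the difference between the two cores is not broken down here. Its value is the lowest of the three, and its steps to compound 1 and to compound 2 are both beyond the scatter, so compound 3 is the strongest inhibitor among the measured compounds.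

Compound 4, `CCC(C)(C)/N=c1\c(O)c(O)\c1=N/Cc1ccc(F)c(Cl)c1`, has not been measured. It differs from compound 3 by chloro in place of hydrogen on an aromatic carbon. For the measured compounds named here, this is the same kind of change as the one from compound 2 to compound 1, though not the same: there the entering chloro sat ortho to a large group and meta to a chloro group, here it sits ortho to a fluoro group and meta to a large group.

Going by the values given here, with only one earlier example of this kind of change, which stayed within the scatter, compound 4 is expected to land close to compound 3, the step being estimated at a 1.2-fold lower number from compound 3 to compound 4 (0.08 log units; within the scatter). In this assay compound 4 is therefore estimated at 300 nM, most likely between 120 nM and 800 nM.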

Compound 4, half-maximal inhibitory concentration: 870 nM
The estimate for compound 4 lay 2.9-fold (0.46 log units) below the measured number; the whole stated range lies below it.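

In this assay, putting chloro in place of hydrogen on an aromatic carbon of compound 3 gave a 2.4-fold higher number from compound 3 to compound 4 (0.38 log units; beyond the scatter), a modest but real weakening of inhibition. For the compounds shown here, the earlier step on the other core stayed within the scatter, so the effect of this change cannot simply be carried from one core to the other: the same change on two cores in this assay, a 1.3-fold lower number (0.12 log units; within the scatter) from compound 2 to compound 1 and a 2.4-fold higher number (0.38 log units; beyond the scatter) from compound 3 to compound 4, 3.2-fold (0.50 log units) apart, beyond the scatter of two such steps This does not show that the core alone sets the size of the step, since the two pairs also differ in the surroundings of the new chloro, which in compound 4 sits ortho to a fluoro group and meta to a large group, a different place from the one it takes in compound 1, and two steps are too few to separate these factors or to make a rule.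

The compounds shown leave open how a methyl or methoxy group at that same place on the ring of compound 3 would read in this assay, and whether a chloro there would give a similar step with hydrogen in place of the fluoro group. Also open, on these data alone, is whether the step would hold with a longer chain in place of the branched alkyl group.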